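Phenyl for amino on the shared core: compound 3

This account rests on a few compounds, and the source may have more. Where it says the series, first, only, none or still open, it means among the compounds named here.

Measured so far:
- compound 1 `C#CCOc1ccc(-c2cc(-c3ccccc3OCC#C)nc(N)n2)cc1` — 22100 nM
- compound 2 `C#CCOc1ccc(-c2cc(-c3cccc(OCC#C)c3)nc(C)n2)cc1` — 8090 nM

Both numbers come from an assay on BTI-TN-5B1-4 cells for inhibition of Amine oxidase [flavin-containing] B (Homo sapiens), read by fluorescence and Amplex Red, using microsomes, with a stated time of 30 min; a lower number here means a stronger inhibitor, a higher number a weaker inhibitor. Compound 1 gives 22100 nM and stands at the highest of the two numbers; compound 2 gives 8090 nM, a lower number, and the gap between the two lies beyond the scatter. Among the compounds with values here, compound 2 differs from compound 1 in more than one place, so no single step between them can be read off; only the two values themselves are known.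

Compound 3 `C#CCOc1ccc(-c2cc(-c3ccccc3OCC#C)nc(-c3ccccc3)n2)cc1` differs from compound 1 in one place: phenyl in place of amino on an aromatic carbon. Within the data shown here, no measured pair isolates this change. With only a loose hint from compound 2 that a carbon group in place of amino goes with a lower number, a modest downward step is expected, not beyond the scatter with confidence. For compound 3 the estimated step is a 1.7-fold lower number from compound 1 to compound 3 (0.23 log units; within the scatter). Compound 3 is thus expected at about 13000 nM, with a range of 4000 nM to 40000 nM.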

Compound 3, half-maximal inhibitory concentration: 14400 nM
Estimate against measurement, compound 3: 1.1-fold (0.04 log units) below, within the range that was stated.
By their numbers in this assay, from the lowest: compounds 2, 3 and 1 (each within the scatter of the next, the first and the last beyond it).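

In this assay, phenyl in place of amino on an aromatic carbon between two ring nitrogen atoms gives a 1.5-fold lower number from compound 1 to compound 3 (0.19 log units; within the scatter). Within the data shown here, this is the first single-place reading at this position: six heavy atoms and a six-membered aromatic ring of carbon only can enter, and the amino group with its hydrogen-bond donor and acceptor can leave, without a shift beyond the scatter. No separate measurement bears on this result.

On these data alone, whether a carboxylic acid, a dimethylamino group or a longer chain such as butyl at this position would give a step beyond the scatter remains open. Also open, as far as these compounds go, is whether phenyl in place of methyl on the core of compound 2 would give a similar step.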